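Chain-length extension from compound 3 to compound 4

The compounds below may be only part of what the source reports. "The series", "measured", "known", "first", "only" and "open" are said of these compounds alone.

In a functional assay on MCF7 cells (Homo sapiens) for cytotoxicity (a lower number here means a stronger inhibitor, a higher number a weaker inhibitor), compound 3 `N#C/N=C1\N(CCCCCCOc2ccc(Cl)cc2)C(=O)CCN1c1ccncc1` gives 454 nM, the lowest of the three numbers recorded so far. Compound 1 `N#C/N=C1\N(CCCCCCOc2ccc(Cl)cc2)C(=O)C(c2ccccc2)N1c1ccncc1` gives 1130 nM in this assay. Compound 2 `N#C/N=C1\N(CCCCCOc2ccc(Cl)cc2)C(=O)CCN1c1ccncc1` gives 5460 nM in this assay. Compound 4 `N#C/N=C1\N(CCCCCCCOc2ccc(Cl)cc2)C(=O)CCN1c1ccncc1` is not yet measured; it differs from compound 3 by (4-chlorophenoxy)methyl in place of 4-chlorophenoxy on a saturated chain carbon, six bonds along the chain from an amide-type nitrogen in a ring. Among the measured compounds shown here, the one measured step that bears on this change is the same kind of lengthening one bond nearer the ring: a 12-fold lower number from compound 2 to compound 3 (1.08 log units; beyond the scatter). Whether a further lengthening carries on in the same direction cannot be told from a single step, and compound 1, which differs from compound 3 in another place, says nothing about chain length. The expectation is therefore a step of uncertain direction, estimated as a 1.1-fold lower number from compound 3 to compound 4 (0.05 log units; within the scatter), with the range kept wide. Compound 4 is expected to give about 400 nM in this assay, between 150 nM and 1200 nM.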

Compound 4, half-maximal inhibitory concentration: 6840 nM
Estimate against measurement, compound 4: 17-fold (1.23 log units) below; measured number outside the range, above it.
By their numbers in this assay, from the lowest: compound 3; then compound 1; then compounds 2 and 4 (each within the scatter of the next).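

In this assay, the lengthening that helped one bond nearer the ring does not carry on: a 15-fold higher number from compound 3 to compound 4 (1.18 log units; beyond the scatter), which reverses the earlier 12-fold lower number from compound 2 to compound 3 (1.08 log units; beyond the scatter). The chain of compound 3 therefore stands alone among these three chain lengths on the shared core, while the shorter and longer neighbours fall level with each other, with a 1.3-fold higher number from compound 2 to compound 4 (0.10 log units; within the scatter). Nothing at hand accounts for this sharp turn at a single added carbon.

Still open is whether a longer chain than that of compound 4 stays at this level or changes again, and whether the same turn appears on the core of compound 1, which is shown with only one chain length. Also open, going by these compounds, is how the chain responds when an amine takes the place of the ether oxygen.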